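Chalcone series, antiproliferative notes on a single change

This account rests on a few compounds, and the source may have more. Where it says the series, first, only, none or still open, it means among the compounds named here.

Measured compounds:
compound 1, `COc1cc(OC)c(OC)cc1/C=C/C(=O)c1ccc(OC)c2c1OC(C)(C)C=C2`, > 10000 nM
compound 2, `COc1ccc(C(=O)/C=C/c2ccc(C(F)(F)F)cc2)c2c1C=CC(C)(C)O2`, > 10000 nM

In a functional assay on SW-620 cells (Homo sapiens) for antiproliferative activity, read by MTT assay, with a stated time of 24 h (a higher number here means a weaker inhibitor, a lower number a stronger inhibitor), compound 1 gives > 10000 nM, which is a limit of the assay and not a number. Compound 2 likewise returns only a limit in this assay, > 10000 nM. Both shown values therefore sit at the limit of > 10000 nM in this assay, at which 2 of the 2 values shown sit; compound 2 stands at that limit, and nothing in the numbers separates it from compound 1.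

Compound 3, `COc1ccc(C(=O)/C=C/c2ccc(O)cc2)c2c1C=CC(C)(C)O2`, differs from compound 2 in one place: hydroxy in place of trifluoromethyl on an aromatic carbon. No measured step of this kind exists in the set, so the size of the change cannot be read from the shown compounds. With compound 2 sitting at the limit of > 10000 nM in this assay, at which 2 of the 2 values shown sit, the expected outcome is a step that the limit leaves unreadable from compound 2 to compound 3, that is, none beyond the scatter, with a substantial chance that compound 3 again returns only a limit. Compound 3 is estimated at 12000 nM, with a range from 3000 nM to 40000 nM.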

Compound 3, half-maximal inhibitory concentration: > 10000 nM
Compound 3 gave a limit, no number; the forecaster's own chance of this, stated with the estimate: 60%; the middle value does not contradict the limit.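

In this assay compound 2 and compound 3 both return only a limit and no number, so no step can be read for hydroxy in place of trifluoromethyl. The compounds shown leave open how compound 1, compound 2 and compound 3 rank against one another, since all sit at one limit: the limit of > 10000 nM in this assay, at which 3 of the 3 values shown sit.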